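Fluoro to nitro on the carbon-only aromatic ring

The source may hold more compounds than are shown below. What is called first, only, known or untested is meant among the compounds shown, and "the series" means these compounds.

Compound 2 `O=C(O)CCCC/C=C(\c1cccnc1)c1cccc(F)c1` carries fluoro on the carbon-only aromatic ring. For the measured compounds named here, in an assay (Equus caballus) for inhibition of Thromboxane-A synthase (Homo sapiens), using microsomes (a lower number here means a stronger inhibitor, a higher number a weaker inhibitor), compound 2 gives 55 nM, the lowest of the two numbers measured so far. Its nearest neighbour is compound 1 `O=C(O)CCCC/C=C(\c1cccnc1)c1cccc(Br)c1`, which in this assay gives 180 nM. Going by the values given here, the step of a 3.3-fold lower number from compound 1 to compound 2 (0.51 log units; beyond the scatter) is the only measured step and the only one that bears on the next change. Compound 3 `O=C(O)CCCC/C=C(\c1cccnc1)c1cccc([N+](=O)[O-])c1` differs from compound 2 by nitro in place of fluoro on an aromatic carbon. The one measured step exchanges one halogen for another at the same carbon and was modest; no measured step exchanges a halogen for nitro, so the direction is not shown by the data. A change no larger than the measured step, in either direction, is expected, so for compound 3 the estimated step is a 1.8-fold higher number from compound 2 to compound 3 (0.26 log units; within the scatter). The estimate for compound 3 in this assay is 100 nM, within 30 nM to 350 nM.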

Compound 3, half-maximal inhibitory concentration: 73 nM
Compound 3: middle estimate off by 1.4-fold (0.14 log units), on the high side; measured number inside the range.
By their numbers in this assay, from the lowest: compounds 2 and 3 (each within the scatter of the next); then compound 1.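

In this assay, nitro in place of fluoro on this aromatic carbon gives a 1.3-fold higher number from compound 2 to compound 3 (0.12 log units; within the scatter), so this position takes nitro, with its three heavy atoms and two hydrogen-bond acceptors, without a change beyond the scatter from the fluoro compound. Against the bromo compound, the same nitro group gives a 2.5-fold lower number from compound 1 to compound 3 (0.39 log units; beyond the scatter), which leaves compound 1 apart from both compound 2 and compound 3 and shows that the difference seen earlier was not simply one between fluoro and every other group. Nothing on hand accounts for these numbers.

As far as these compounds go, whether an amine or a methoxy group on this carbon would read with compound 2 and compound 3 or with compound 1 remains open. Also open, from the compounds shown here alone, is how plain hydrogen at this position compares with all three.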